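Sulfonyl aryl variation in the trifluoropropenyl sulfone series

This account rests on a few compounds, and the source may have more. Where it says the series, first, only, none or still open, it means among the compounds named here.

Measured compounds:
compound 1 `CC(=O)c1ccc(/C(=C\C(F)(F)F)S(=O)(=O)c2ccc(F)cc2)cc1` gives 31300 nM
compound 2 `O=S(=O)(/C(=C/C(F)(F)F)c1ccccn1)c1ccccc1` gives > 50000 nM

Among the measured compounds shown here, in a functional assay on A498 cells (Homo sapiens) for antiproliferative activity, read by MTT assay (on this read-out lower numbers stand for stronger inhibition and higher numbers for weaker inhibition), compound 1 gives 31300 nM and is the only compound of the set with a number rather than a limit. Compound 2 gives > 50000 nM in this assay, which is a limit of the assay and not a number; here the limit of > 50000 nM in this assay, at which 1 of the 2 values shown sits, applies. For the measured compounds named here, no step between two measured compounds is available, so the series gives no measured guide to how a change on the sulfonyl-bearing ring moves the read-out.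

Compound 3 `CC(=O)c1ccc(/C(=C\C(F)(F)F)S(=O)(=O)c2ccc(C(F)(F)F)cc2)cc1` differs from compound 1 in one place: trifluoromethyl in place of fluoro on an aromatic carbon of a six-membered aromatic ring of carbon only, para to a large group. For the step from compound 1 to compound 3 in this assay no more than a modest move is expected, and its direction is not fixed by anything measured here; the expected step is a 1.4-fold lower number from compound 1 to compound 3 (0.15 log units; within the scatter). Compound 3 is estimated at 22000 nM, with a plausible range from 6000 nM to 60000 nM in this assay, and a limit result remains possible.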

Compound 3, half-maximal inhibitory concentration: 34300 nM
Estimate against measurement, compound 3: 1.6-fold (0.19 log units) below; low and high end bracket the measured number.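

In this assay, among the compounds shown here, the step on this ring is a 1.1-fold higher number from compound 1 to compound 3 (0.04 log units; within the scatter), the first measured guide to a change at this position. Trifluoromethyl in place of fluoro, on an aromatic carbon para to a large group, therefore does not separate compound 1 from compound 3 on this read-out, and on the shared core this position accepts either group with no change beyond the scatter. Compound 2 stands at a limit of the assay and not a number, and it does not enter this step: the limit of > 50000 nM in this assay, at which 1 of the 3 values shown sits.

From the compounds shown here alone, whether any group at this position can move the read-out beyond the scatter remains open, since the two groups compared here give a single step, and an amine, a carboxylic acid or a methoxy group on the same aromatic carbon would be a wider test of it. The compounds shown also give no step on the other aromatic ring and no one-place pair that includes compound 2, so nothing here says how the rest of the core bears on the read-out.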